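Trifluoromethyl for Nitro: A Step From the Assay Limit

The compounds below may be only part of what the source reports. "The series", "measured", "known", "first", "only" and "open" are said of these compounds alone.

This account starts with compound 1, `Cc1cc(O)c(C(=O)/C=C/c2ccccc2[N+](=O)[O-])c(=O)o1`, tested in a functional assay on HCT-116 cells (Homo sapiens) for cytotoxicity, read by MTT assay; a lower number here means a stronger inhibitor, a higher number a weaker inhibitor. In this assay, compound 1 gives > 100000 nM, which is a limit of the assay and not a measured number. Among the compounds with values here, its only measured neighbour is compound 2, `Cc1cc(O)c(C(=O)/C=C/c2ccc(F)cc2)c(=O)o1`, which shares the core of compound 1 but carries a different substituent on the aromatic ring. Compound 2 gives > 100000 nM, again a limit and not a number. Both compounds therefore stand at the same boundary: the limit of > 100000 nM in this assay, at which 2 of the 2 values shown sit.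

The next compound is compound 3, `Cc1cc(O)c(C(=O)/C=C/c2ccccc2C(F)(F)F)c(=O)o1`. It has trifluoromethyl in place of nitro on an aromatic carbon, and the rest of the structure stays as it is in compound 1: trifluoromethyl in place of nitro on an aromatic carbon. The new group sits at the same place, ortho to a large group.

Within the data shown here, no measured pair shows what this exchange does, so the expectation rests only on those two limits. The expected change is a number no higher from compound 1 to compound 3 (the limit leaves the size open), which means no step beyond the scatter of repeat measurements. The assay may well report only a limit again. For compound 3 the estimated value is 100000 nM, with an expected range from 50000 nM to 200000 nM.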

Compound 3, half-maximal inhibitory concentration: > 100000 nM
Compound 3 ended at the assay's limit; the forecaster's own chance of this, stated with the estimate: 75%; the middle value sits exactly at the limit.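

Compound 3 gives > 100000 nM, which is a limit of the assay and not a number. Within the data shown here, compound 1 also stands at a limit, so no step from compound 1 to compound 3 can be read. All the compounds shown share one boundary: the limit of > 100000 nM in this assay, at which 3 of the 3 values shown sit. They leave open whether trifluoromethyl or nitro makes any difference in this assay, and what change to the shared core, if any, would give a measured number.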